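The compounds below may be only part of what the source reports. "The series", "measured", "known", "first", "only" and "open" are said of these compounds alone.

In a functional assay on HGC-27 cells (Homo sapiens) for cytotoxicity, read by MTT assay, with a stated time of 48 h (a higher number here means a weaker inhibitor, a lower number a stronger inhibitor), compound 1 (`COc1cc(OC)c(OC)cc1/C=C/C(=O)/C=C/c1cc2ccccc2nc1Cl`) gives 8730 nM and compound 2 (`COc1cc(OC)c(OC)cc1/C=C/C(=O)/C=C/c1cc2ccccc2nc1Oc1ccccc1`) gives 10500 nM. Swapping the group on the core between them gives a 1.2-fold higher number from compound 1 to compound 2 (0.08 log units; within the scatter). Compound 3 (`COc1ccc(OC)c(/C=C/C(=O)/C=C/c2cc3ccccc3nc2Oc2cccc(Cl)c2)c1`) stands at > 10000 nM, which is a limit of the assay and not a number. Compound 4 (`COc1cc(OC)c(OC)cc1/C=C/C(=O)/C=C/c1cc2ccccc2nc1Oc1cccc(Cl)c1`) differs from compound 3 by methoxy in place of hydrogen on an aromatic carbon, turning 2,5-dimethoxyphenyl into 2,4,5-trimethoxyphenyl. For the measured compounds named here, no measured step makes this change directly. The nearest guide is compound 2, which already carries 2,4,5-trimethoxyphenyl and gives 10500 nM. Little movement in this assay is therefore expected, with no clear direction, and the expected step is an at least 1.0-fold lower number from compound 3 to compound 4 (0.02 log units; that floor lies within the scatter). For compound 4 the estimated value is 9500 nM, with an expected range of 4000 nM to 22000 nM.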

Compound 4, half-maximal inhibitory concentration: > 10000 nM
Compound 4 was reported as a limit; the forecaster's own chance of this, stated with the estimate: 40%; middle value at least 1.0-fold (0.02 log units) from the limit.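

Compound 4 reads only as a limit in this assay, so neither adding methoxy to compound 3 nor adding chloro to compound 2 can be read as a step. The one readable step is an at least 1.1-fold higher number from compound 1 to compound 4 (0.05 log units; that floor lies within the scatter), so swapping chloro for 3-chlorophenoxy is not shown to matter. Compound 3 and compound 4 cannot be ranked, because they share one limit: the limit of > 10000 nM in this assay, at which 2 of the 4 values shown sit.

Going by these compounds, whether methoxy changes anything at this position remains unknown while both values are limits. On these data alone, it is also open whether an amine or a carboxylic acid in place of 3-chlorophenoxy would give a lower number.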